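The source may report more compounds than this note shows. Statements on the series, on what has been measured and on what is new or still open speak of the compounds shown alone.

Working notes on a small set of brominated catechol benzyl alcohols tested in a functional assay on DLD-1 cells (Homo sapiens) for cytotoxicity, read by MTT assay, with a stated time of 96 h; a lower number here means a stronger inhibitor, a higher number a weaker inhibitor.

Compound 1 `OCc1cc(O)c(O)c(Br)c1` is the parent. In this assay compound 1 gives 51500 nM. Compound 2 `COCc1cc(O)c(O)c(Br)c1` differs from compound 1 by methyl in place of hydrogen on an oxygen on a saturated carbon and in this assay compound 2 gives 35300 nM, a step of a 1.5-fold lower number from compound 1 to compound 2 (0.16 log units; within the scatter). Compound 3 `OCc1cc(O)c(O)c(Br)c1Br` differs from compound 1 by bromo in place of hydrogen on an aromatic carbon; in this assay compound 3 gives 18300 nM, a step of a 2.8-fold lower number from compound 1 to compound 3 (0.45 log units; beyond the scatter). Compound 3 carries the lowest number of the three, with compound 2 nearest to it and within the scatter, so no order between compound 2 and compound 3 is claimed.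

Compound 4 `COCc1cc(O)c(O)c(Br)c1Br` has not yet been measured. It differs from compound 3 by methyl in place of hydrogen on an oxygen on a saturated carbon, the same change that takes compound 1 to compound 2, and made at the same place as described for that pair; the two cores differ by the bromo in place of hydrogen already stated for compound 3 against compound 1.

Among the measured compounds shown here, the step from compound 1 to compound 2 was a 1.5-fold lower number from compound 1 to compound 2 (0.16 log units; within the scatter), within the scatter, and no other example of this change is available, so a step of similar size is the working expectation. For compound 4 the step is expected to be a 1.4-fold lower number from compound 3 to compound 4 (0.15 log units; within the scatter). In this assay compound 4 is estimated at 13000 nM, with a range from 6000 nM to 30000 nM given that it rests on a single earlier step of compound 1 to compound 2 a 1.5-fold lower number from compound 1 to compound 2 (0.16 log units; within the scatter).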

Compound 4, half-maximal inhibitory concentration: 14600 nM
For compound 4 the middle estimate is 1.1-fold (0.05 log units) below the measured one, within the range that was stated.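

In this assay the methyl on the oxygen of the hydroxymethyl group gives a 1.3-fold lower number from compound 3 to compound 4 (0.10 log units; within the scatter), and this small step matches the earlier one on the other core: the same change on two cores in this assay, a 1.5-fold lower number (0.16 log units; within the scatter) from compound 1 to compound 2 and a 1.3-fold lower number (0.10 log units; within the scatter) from compound 3 to compound 4, 1.2-fold (0.07 log units) apart, within the scatter of two such steps. The bromo change gives a 2.4-fold lower number from compound 2 to compound 4 (0.38 log units; beyond the scatter), so it stays a modest step beyond the scatter whether the group on the saturated carbon is hydroxymethyl or methoxymethyl: the same change on two cores in this assay, a 2.8-fold lower number (0.45 log units; beyond the scatter) from compound 1 to compound 3 and a 2.4-fold lower number (0.38 log units; beyond the scatter) from compound 2 to compound 4, 1.2-fold (0.07 log units) apart, within the scatter of two such steps. The two changes therefore behave as independent steps across these four compounds, but this rests on a single pair of cores for each change. The methyl step lies within the scatter on both cores. This shows only that hydroxymethyl and methoxymethyl are not told apart here, and says nothing about why the bromo step carries over or whether either step would hold on a different core.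

Still open, going by these compounds, is whether a longer chain on that oxygen, such as ethyl or benzyl, would move the number beyond the scatter, and whether an amine or a carboxylic acid in place of hydroxymethyl would do so. Also open, on these data alone, is whether the bromo step is particular to bromine or would appear with chloro or iodo on the same aromatic carbon.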